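Swapping Fluoro for 2-Methoxyethoxy on Compound 1

This account rests on a few compounds, and the source may have more. Where it says the series, first, only, none or still open, it means among the compounds named here.

Measured so far:
compound 1, `CC(C)(C)Cc1c(-c2ccc(F)cc2)sc(N)c1C(=O)c1ccc(Cl)cc1`, 9%
compound 2, `COc1cccc(-c2sc(N)c(C(=O)c3ccc(Cl)cc3)c2CC(C)(C)C)c1`, 1%
compound 3, `COc1ccccc1-c1sc(N)c(C(=O)c2ccc(Cl)cc2)c1CC(C)(C)C`, 1%

In an assay on CHO cells for displacement of a labelled ligand from adenosine receptor A3 (Homo sapiens), read by scintillation counting, tested at 10 uM (on this read-out lower numbers stand for less inhibition and higher numbers for more inhibition at the one concentration tested (going by the name of the read-out)), compound 1 gives 9%, the largest of the three numbers, yet both of its steps stay within the scatter: a number 8 percentage points lower from compound 1 to compound 2 (within the scatter) and a number 8 percentage points lower from compound 1 to compound 3 (within the scatter). Between the two methoxyphenyl analogues there is no change at the digits printed from compound 2 to compound 3 (within the scatter). Compound 4, `COCCOc1ccc(-c2sc(N)c(C(=O)c3ccc(Cl)cc3)c2CC(C)(C)C)cc1`, differs from compound 1 by 2-methoxyethoxy in place of fluoro on an aromatic carbon. Among the measured compounds shown here, no measured step alters this group; the three steps all concern the other aryl ring and were each within the scatter, and every value is low. The expected step in this assay is therefore a number 4 percentage points lower from compound 1 to compound 4 (within the scatter), none beyond the scatter. Compound 4 is estimated at 5%, in the range 0% to 20%.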

Compound 4, a percentage reported as inhibition, at one concentration (the size of the read-out at that concentration, not a potency): 1%
Compound 4: middle estimate off by 4 percentage points, on the high side; the measured number falls inside the stated range.
By their numbers in this assay, from the lowest: compounds 2, 3, 4 and 1 (each within the scatter of the next).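

In this assay 2-methoxyethoxy in place of fluoro on the aromatic carbon para to a large group gives a number 8 percentage points lower from compound 1 to compound 4 (within the scatter) and so brings no step beyond the scatter. The earlier steps shown here only exchanged fluoro and methoxy aryl rings, whereas this one shows that a longer chain with hydrogen-bond acceptors at this position also leaves the number low. No evidence is available that bears on this result. Going by these compounds, whether an amine or a carboxylic acid at this position would raise the number beyond the scatter remains open.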